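Trifluoromethyl in place of methoxy: expected half-life shift

The source may report more compounds than this note shows. Statements on the series, on what has been measured and on what is new or still open speak of the compounds shown alone.

In an ADME assay on the whole organism (Mus musculus, strain CD1) for metabolic stability, at a dose of 2 mg/kg by the intravenous route (a lower number here means that the compound disappears faster, a higher number that the compound lasts longer), compound 1 `COc1cc(N2C(=O)C3(CCC3)N(c3ccc(OC4CCN(C)CC4)nc3)C2=S)cnc1C#N` gives 4.2 h, the lower of the two numbers available. Compound 2 `CN1CCC(Oc2ccc(N3C(=S)N(c4cnc(C#N)c(C(F)(F)F)c4)C(=O)C34CCC4)cc2)CC1` gives 46.4 h, and that gap lies beyond the usual scatter. Compound 3 `CN1CCC(Oc2ccc(N3C(=S)N(c4cnc(C#N)c(C(F)(F)F)c4)C(=O)C34CCC4)cn2)CC1` differs from compound 1 in one place, where 6-cyano-5-methoxypyridin-3-yl becomes 6-cyano-5-(trifluoromethyl)pyridin-3-yl trifluoromethyl in place of methoxy on an aromatic carbon, ortho to a cyano group. Among the measured compounds shown here, no measured step isolates this change, so the data give no direct size for it. For the measured compounds named here, the expectation rests on the two values alone, with compound 2 at 46.4 h as the only higher number. A rise in this assay beyond the scatter is expected, though smaller than that gap. The expected size is a 3.6-fold higher number from compound 1 to compound 3 (0.55 log units; beyond the scatter). Compound 3 is estimated at 15 h, with an expected range of 5 h to 42 h.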

Compound 3, half-life: 12.5 h
The estimate for compound 3 lay 1.2-fold (0.08 log units) above the measured number; the measured number falls inside the stated range.
By their numbers in this assay, from the lowest: compound 1; then compound 3; then compound 2.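

In this assay trifluoromethyl in place of methoxy on an aromatic carbon, ortho to a cyano group, gives a 3.0-fold higher number from compound 1 to compound 3 (0.47 log units; beyond the scatter) and so puts a first direct size on this change at this position. The step is modest: compound 3 at 12.5 h still sits under compound 2 at 46.4 h even though both carry trifluoromethyl, so this group does not by itself set the number in the series. Among the compounds shown here, nothing measured so far accounts for the rise in half-life.

Open, from the compounds shown here alone, is how chlorine or a methyl group on this same aromatic carbon would compare with methoxy and trifluoromethyl. Also open, going by these compounds, is whether the step keeps its size when the same change is made with the rest of compound 2 held fixed.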